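The compounds below may be only part of what the source reports. "The series", "measured", "known", "first", "only" and "open" are said of these compounds alone.

In a functional assay on ECa-109 cells for inhibition, with ECa-109 cell line (Homo sapiens) as the target, read by sulforhodamine B assay (on this read-out higher numbers stand for weaker inhibition and lower numbers for stronger inhibition), compound 1 `O=C1C(Nc2ccc(I)cc2)=CC(=O)c2c1nc1n2[C@H]2OC[C@@H](O)[C@H]2OC1` gives 2530 nM. Compound 2 `O=C1C=C(Nc2ccccc2F)C(=O)c2c1nc1n2[C@H]2OC[C@@H](O)[C@H]2OC1` gives 2760 nM. Compound 3 `O=C1C=C(NC2CCCCC2)C(=O)c2c1nc1n2[C@H]2OC[C@@H](O)[C@H]2OC1` gives only a limit of the assay, > 16000 nM.

Compound 1 has the lowest of the two numbers, with compound 2 within the scatter of it. Compound 4 `CCCc1ccc(NC2=CC(=O)c3c(nc4n3[C@H]3OC[C@@H](O)[C@H]3OC4)C2=O)cc1` differs from compound 1 by propyl in place of iodo on an aromatic carbon. Among the measured compounds shown here, the one measured step, an at least 5.7-fold higher number from compound 2 to compound 3 (0.76 log units; beyond the scatter), swaps the whole aromatic ring on the amine nitrogen for cyclohexyl; it does not test a change of a substituent on that ring, so it gives little guidance here. Keeping the aromatic ring, only a step within the scatter is expected, a 1.0-fold lower number from compound 1 to compound 4 (0.01 log units; within the scatter). Compound 4 is therefore estimated at 2500 nM, between 1000 nM and 6500 nM.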

Compound 4, half-maximal inhibitory concentration: > 4000 nM
Compound 4 was reported as a limit (the forecaster's own chance of this, stated with the estimate: 10%); middle value at least 1.6-fold (0.20 log units) from the limit.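

Among the compounds shown here, this is the first step that changes only a substituent on the aromatic ring, with the ring itself kept: an at least 1.5-fold higher number from compound 1 to compound 4 (0.19 log units; that floor lies within the scatter). For compound 4 the assay gives a limit rather than a number, > 4000 nM. The true size of the step therefore stays unknown, and even its floor does not separate the pair, because the reading stops at a limit: the limit of > 4000 nM in this assay, at which 1 of the 4 values shown sits.

As far as these compounds go, whether a shorter chain such as methyl or ethyl, or another halogen such as bromo, at this place stays close to compound 1 remains open.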